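Cinnamamide series: amide side-chain variation and binding

The source may hold more compounds than are shown below. What is called first, only, known or untested is meant among the compounds shown, and "the series" means these compounds.

Measured so far:
- compound 1, `CC(C)[C@@H](NC(=O)/C=C/c1ccncc1-c1ccc2ccccc2c1)C(=O)O`: 77%
- compound 2, `Cn1ccc2cc(-c3cnccc3/C=C/C(=O)N3CCOCC3)ccc21`: 97%
- compound 3, `CN1CCN(C(=O)/C=C/c2ccncc2-c2ccc(F)cc2)CC1`: 84%

All three were run in an assay on a protein complex for inhibition of CDK8/Cyclin C (Homo sapiens), with a stated time of 1 h, tested at 10 uM; on this read-out lower numbers stand for less inhibition and higher numbers for more inhibition at the one concentration tested (going by the name of the read-out). Compound 1 gives 77% and stands lowest of the three numbers. Compound 3 gives 84%, which sits within the usual scatter of compound 1, so no order between these two can be claimed. Compound 2 gives 97%, and the gap to compound 1 lies beyond the scatter; compound 2 is thus the only one of the three that clearly stands above compound 1. Within the data shown here, no step between two measured compounds that differ in a single place is available, so the effect of changing the amide-type nitrogen substituent alone has not yet been isolated.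

Compound 4, `O=C(O)CCNC(=O)/C=C/c1ccncc1-c1ccc2ccccc2c1`, is the next compound for this assay. It differs from compound 1 in one place: 2-carboxyethyl in place of 1-carboxy-2-methylpropyl on an amide-type nitrogen. The carboxylic acid is retained, and the change leaves the rest of the molecule, including the shared core, untouched.

Among the measured compounds shown here, with no single-point step available, the size of the change from compound 1 is unknown. Compound 4 is expected to give a number close to that of compound 1, with a step estimated as a number 5 percentage points lower from compound 1 to compound 4 (within the scatter) and most likely not beyond the scatter. The estimate for compound 4 in this assay is 72%, in the range 50% to 90%.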

Compound 4, a percentage reported as inhibition, at one concentration (the size of the read-out at that concentration, not a potency): 91%
Estimate against measurement, compound 4: 19 percentage points below; measured number above the stated range.
By their numbers in this assay, from the lowest: compounds 1, 3, 4 and 2 (each within the scatter of the next, the first and the last beyond it).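

In this assay, among these compounds, the swap of 1-carboxy-2-methylpropyl for 2-carboxyethyl on the amide-type nitrogen gives the first single-place step, a number 14 percentage points higher from compound 1 to compound 4 (beyond the scatter), which shows that this position responds to the side chain even with the carboxylic acid retained. The entering group is the smaller of the two and has no defined stereocentre, while its hydrogen-bond donor and acceptor counts match those of the leaving group, so neither the extra heavy atoms nor the stereocentre of 1-carboxy-2-methylpropyl is required for the read-out on this core. No measured information on the origin of this step is available.

The single step changes chain size and stereocentre together, and the compounds shown do not separate the contribution of each. Also open, from the compounds shown here alone, is how much the carboxylic acid itself contributes at this position, which a 2-hydroxyethyl or 2-aminoethyl group on the same core would test, while a longer chain ending in a carboxylic acid would show whether the number in this assay is higher, lower or level with further extension.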